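The source may hold more compounds than are shown below. What is called first, only, known or untested is meant among the compounds shown, and "the series" means these compounds.

Measured in a functional assay on HCT-116 cells (Homo sapiens) for antiproliferative activity, read by MTT assay, with a stated time of 48 h; a lower number here means a stronger inhibitor, a higher number a weaker inhibitor:
- compound 1 `COc1ccc(CN(C(=O)CSc2nc3ccccc3s2)c2cc(OC)c(OC)c(OC)c2)cc1[N+](=O)[O-]`: 1280 nM
- compound 2 `COc1ccc(CN(C(=O)CSc2nc3cc(Cl)ccc3s2)c2cc(OC)c(OC)c(OC)c2)cc1O`: 429 nM

Compound 1 holds the higher of the two numbers. At 429 nM, compound 2 lies lower by a gap beyond the usual scatter. Among the measured compounds shown here, the two compounds differ in more than one place, so this gap cannot be assigned to any single change, and no measured pair isolates one.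

The next compound, compound 3 `COc1ccc(CN(C(=O)CSc2nc3ccccc3s2)c2cc(OC)c(OC)c(OC)c2)cc1C(F)(F)F`, keeps the rest of compound 1 and carries trifluoromethyl in place of nitro on an aromatic carbon, ortho to a methoxy group: trifluoromethyl in place of nitro on an aromatic carbon. For the measured compounds named here, the data hold no measured example of this exchange. The expectation therefore starts from compound 1 at 1280 nM, and no step beyond the scatter is expected in this assay, with no firm direction. The expected change is a 1.3-fold lower number from compound 1 to compound 3 (0.11 log units; within the scatter), which stays within the scatter. Going by the values given here, the range is kept wide, as only two measured compounds are available. The estimate for compound 3 is 1000 nM, with an expected range from 320 nM to 3000 nM.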

Compound 3, half-maximal inhibitory concentration: > 80000 nM
Compound 3: a limit, no number (the forecaster's own chance of this, stated with the estimate: 3%); middle value at least 80-fold (1.90 log units) away from the limit.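

At the position ortho to a methoxy group, the exchange of nitro for trifluoromethyl is far from neutral in this assay: 4-methoxy-3-nitrophenyl to 4-methoxy-3-(trifluoromethyl)phenyl gives an at least 62-fold higher number from compound 1 to compound 3 (1.79 log units; beyond the scatter). In this assay compound 3 gives > 80000 nM, which is a limit of the assay and not a number. The direction of this step is secure and shows that this one position can decide whether the series reads at all in this assay, but its full size stays unfixed: the limit of > 80000 nM in this assay, at which 1 of the 3 values shown sits.

The compounds shown leave open whether nitro is specially favoured here or trifluoromethyl specially disfavoured, and an amine or a nitrile at this position, set on the core of compound 1, would separate these two readings. The hydroxy group of compound 2 does not settle this, as compound 2 differs from compound 1 in more than one place, and no cause for the step can be drawn from the present data.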